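Aryl Swap on the Triazole Nitrogen: Compound 3 Expected

The compounds below may be only part of what the source reports. "The series", "measured", "known", "first", "only" and "open" are said of these compounds alone.

Two analogues sharing one core have been measured in a functional assay on A549 cells (Homo sapiens) for antiproliferative activity, read by MTT assay, with a stated time of 48 h; on this read-out higher numbers stand for weaker inhibition and lower numbers for stronger inhibition. Compound 1 `N#CC1=C(N)Oc2c(N)cc3nc4ccccc4nc3c2C12C(=O)N(Cc1cnnn1-c1cccc(Br)c1)c1ccccc12` gives 18900 nM. Compound 2 `Cc1ccc(-n2nncc2CN2C(=O)C3(C(C#N)=C(N)Oc4c(N)cc5nc6ccccc6nc5c43)c3ccccc32)cc1Cl` gives 11800 nM, the lower of the two numbers, though the step of a 1.6-fold lower number from compound 1 to compound 2 (0.20 log units; within the scatter) stays within the scatter, so the two compounds cannot be ordered on this evidence.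

Compound 3 `Cc1cc(C)c(-n2nncc2CN2C(=O)C3(C(C#N)=C(N)Oc4c(N)cc5nc6ccccc6nc5c43)c3ccccc32)c(C)c1` has not yet been measured in this assay. It differs from compound 2 in one place: 2,4,6-trimethylphenyl in place of 3-chloro-4-methylphenyl on an aromatic nitrogen. Within the data shown here, this is the same kind of change as the one measured step, an exchange of the aryl group on the aromatic nitrogen of the triazole ring. That step, a 1.6-fold lower number from compound 1 to compound 2 (0.20 log units; within the scatter), did not rise above the scatter, and nothing else among the measured data touches this position. The account therefore expects compound 3 to sit close to compound 2, with a step of a 1.0-fold higher number from compound 2 to compound 3 (0.01 log units; within the scatter) that is not expected to exceed the scatter in either direction. Compound 3 is estimated at 12000 nM, within a range from 5000 nM to 30000 nM.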

Compound 3, half-maximal inhibitory concentration: 12700 nM
Compound 3: middle estimate off by 1.1-fold (0.02 log units), on the low side; the range from low to high includes it.
By their numbers in this assay, from the lowest: compounds 2, 3 and 1 (each within the scatter of the next).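

In this assay, replacing 3-chloro-4-methylphenyl with 2,4,6-trimethylphenyl on the aromatic nitrogen of the five-membered ring gives a 1.1-fold higher number from compound 2 to compound 3 (0.03 log units; within the scatter), and replacing 3-bromophenyl with the same group gives a 1.5-fold lower number from compound 1 to compound 3 (0.17 log units; within the scatter). Both earlier aryl groups carried a halogen, so they could not show what an aryl group built from carbon alone would do; with three methyl groups and no halogen, the new group leaves the number within the scatter of both earlier compounds, and these three aryl groups cannot be ordered at this position. No measurement shown here explains this reading.

As far as these compounds go, all three compounds still carry a six-membered aromatic ring of carbon on that nitrogen, so it remains open whether a carboxylic acid or an amine on that ring, or a longer alkyl chain in place of the ring, would move the number beyond the scatter. The shared core is also identical throughout, leaving open how much the antiproliferative reading depends on its nitrile or its amino groups.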